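Swapping an Indole for a tert-Butylphenyl Group

The source may report more compounds than this note shows. Statements on the series, on what has been measured and on what is new or still open speak of the compounds shown alone.

Of the compounds shown here, three that share a fused two-ring core have been tested in a functional assay on HCT-116 cells (Homo sapiens) for inhibition, read by CCK-8 assay, with a stated time of 48 h; a higher number here means a weaker inhibitor, a lower number a stronger inhibitor. Compound 1 `COc1cc(-c2cc3nccc(-c4cc(OC)c(OC)c(OC)c4)n3n2)cc(OC)c1OC` carries the same trimethoxyphenyl group twice. For compound 1 the result is a limit of the assay rather than a number, > 10000 nM. Compound 2 `Cn1ccc2cc(-c3cc4nccc(-c5ccc(F)cc5)n4n3)ccc21` pairs a methyl-substituted indole with a fluorophenyl group, and in this assay compound 2 gives 2160 nM. Compound 3 `COc1cc(-c2ccnc3cc(-c4ccc5cc[nH]c5c4)nn23)cc(OC)c1OC` keeps one trimethoxyphenyl group and adds a free indole; in this assay compound 3 gives 187 nM, the lowest of the two numbers shown, and its gap to compound 2 lies beyond the usual scatter.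

The next compound, compound 4 `COc1cc(-c2ccnc3cc(-c4ccc(C(C)(C)C)cc4)nn23)cc(OC)c1OC`, differs from compound 3 in one place: 4-(tert-butyl)phenyl in place of 1H-indol-6-yl on an aromatic carbon. Among the compounds with values here, no pair of measured compounds differs in exactly this way, so the step cannot be read off from the data. The two compounds that carry a trimethoxyphenyl group, compound 1 at its limit and compound 3 with its number, span a wide range, and the value of compound 4 is expected to fall between them. The change is expected to amount to an 8.0-fold higher number from compound 3 to compound 4 (0.90 log units; beyond the scatter), a weakening beyond the scatter. Compound 4 is therefore estimated at 1500 nM, with a likely range from 300 nM to 8000 nM.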

Compound 4, half-maximal inhibitory concentration: > 10000 nM
Compound 4 gave a limit, no number (the forecaster's own chance of this, stated with the estimate: 15%); middle value at least 6.6-fold (0.82 log units) away from the limit.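

Replacing 1H-indol-6-yl with 4-(tert-butyl)phenyl on this aromatic carbon of the shared core gives an at least 53-fold higher number from compound 3 to compound 4 (1.72 log units; beyond the scatter), a large step and the first in this set that isolates a single change. It shows that in this assay the trimethoxyphenyl group does not secure a measurable value on its own, since compound 3 and compound 4 both carry it and the outcome still turns on the group at this one carbon. The step gives only a minimum for the true difference, because compound 4 stands at a limit of the assay rather than at a number: the limit of > 10000 nM in this assay, at which 2 of the 4 values shown sit.

The compounds shown leave open which part of the change matters: the group that leaves has a hydrogen-bond donor and a five-membered ring, while the group that enters has neither and brings a tert-butyl group. A plain phenyl ring or a 4-aminophenyl group on the same carbon, with the trimethoxyphenyl group kept in place, would help tell these features apart.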